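Propylation of the thiol in a second naphthyl sugar core

The source may report more compounds than this note shows. Statements on the series, on what has been measured and on what is new or still open speak of the compounds shown alone.

Compound 1 `O[C@@H]1[C@@H](O)[C@H](Oc2ccc(S)c3ccccc23)OC[C@H]1O`: 70 uM
Compound 2 `O[C@@H]1[C@@H](O)[C@H](Oc2ccc3ccc(S)cc3c2)OC[C@H]1O`: 100 uM
Compound 3 `CCCSc1ccc(O[C@@H]2OC[C@@H](O)[C@H](O)[C@H]2O)c2ccccc12`: 30 uM

Three compounds were measured in an ADME assay on HFL1 cells (Homo sapiens) for antiproliferative activity, read by crystal violet staining, with a stated time of 96 h; on this read-out lower numbers stand for an effect already at smaller amounts and higher numbers for an effect only at larger amounts of compound. Compound 1 and compound 2 share the same atoms joined differently; the difference between the two cores is not broken down here. In this assay compound 1 gives 70 uM and compound 2 gives 100 uM, the two lying within the scatter of each other.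

Compound 3 `CCCSc1ccc(O[C@@H]2OC[C@@H](O)[C@H](O)[C@H]2O)c2ccccc12` differs from compound 1 by propyl in place of hydrogen on a sulfur, and this change gave a 2.3-fold lower number from compound 1 to compound 3 (0.37 log units; beyond the scatter).

Compound 4 `CCCSc1ccc2ccc(O[C@@H]3OC[C@@H](O)[C@H](O)[C@H]3O)cc2c1`, not yet measured, differs from compound 2 by propyl in place of hydrogen on a sulfur, the same change at the same kind of place. Because that change gave a 2.3-fold lower number from compound 1 to compound 3 (0.37 log units; beyond the scatter), a step of similar size, a 2.2-fold lower number from compound 2 to compound 4 (0.35 log units; beyond the scatter), is expected here. Compound 4 is therefore estimated at 45 uM, with a range from 25 uM to 90 uM.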

Compound 4, concentration for half-maximal effect: 25 uM
For compound 4 the middle estimate is 1.8-fold (0.26 log units) above the measured one; measured number inside the range.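

In this assay propyl in place of hydrogen on the sulfur again gives a lower number, with a 4.0-fold lower number from compound 2 to compound 4 (0.60 log units; beyond the scatter) on the second core. Going by these compounds alone, this shows only that the change carried over in direction and that its size could not be told apart between the two cores, and it rests on two pairs in a single cell assay, so it does not show that the step would hold on any other core or why the number falls. The two steps compare as follows: the same change on two cores in this assay, a 2.3-fold lower number (0.37 log units; beyond the scatter) from compound 1 to compound 3 and a 4.0-fold lower number (0.60 log units; beyond the scatter) from compound 2 to compound 4, 1.7-fold (0.23 log units) apart, within the scatter of two such steps.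

The compounds shown leave open whether a longer chain or a branched chain on the sulfur would lower the number further. They also leave open whether an amine or a carboxylic acid at the end of the propyl chain would keep the step.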